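The compounds below may be only part of what the source reports. "The series", "measured", "known", "first", "only" and "open" are said of these compounds alone.

Values in a physicochemical assay for solubility, read by LC-MS, in phosphate buffer, with a stated time of 24 h, at pH 7.4; a higher number here means a more soluble compound, a lower number a less soluble compound:

- Compound 1 `Cc1ncccc1-c1cnc(NCc2c(F)ccc3c2CCO3)c2ncc(=O)[nH]c12`: 29000 nM
- Compound 2 `COCCC(=O)Nc1cnc(NCc2c(F)ccc3c2CCO3)n2cnnc12`: 980000 nM
- Compound 3 `CC(=O)N1CCC(c2cnc(NCc3c(F)ccc4c3CCO4)c3cn[nH]c(=O)c23)CC1`: < 2000 nM (a limit, not a number)

Compound 3 stands at the limit of < 2000 nM in this assay, at which 1 of the 3 values shown sits, so its place in the series is known only as a limit.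

Compound 4 `CNC(=O)c1cc(-c2cnc(NCc3c(F)ccc4c3CCO4)c3cn[nH]c(=O)c23)n(C)n1` has not yet been measured. It carries 1-methyl-3-(methylcarbamoyl)-1H-pyrazol-5-yl in place of 1-acetylpiperidin-4-yl on an aromatic carbon.

For the measured compounds named here, no measured pair differs in one place, so this change has no direct precedent. Going by the values given here, compound 1 at 29000 nM and compound 2 at 980000 nM have cores that differ from that of compound 3, and they give no step to carry over. With only the limit of compound 3 as a starting point, a small upward step or none beyond the scatter is expected, and a second limit would be no surprise.

The estimated step is an at least 1.2-fold higher number from compound 3 to compound 4 (0.09 log units; that floor lies within the scatter).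

For compound 4 the expected value is 2500 nM, with an estimated range of 1000 nM to 12000 nM.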

Compound 4, solubility: 7000 nM
Compound 4: the middle estimate sits 2.8-fold (0.45 log units) below what was measured; measured number inside the range.
By their numbers in this assay, from the lowest: compound 4; then compound 1; then compound 2. At a limit, below all of these: compound 3.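

In this assay, for the compounds shown here, 1-methyl-3-(methylcarbamoyl)-1H-pyrazol-5-yl in place of 1-acetylpiperidin-4-yl on an aromatic carbon gives an at least 3.5-fold higher number from compound 3 to compound 4 (0.54 log units; beyond the scatter), the first step between compounds that differ in one place. With the aromatic group at this position, the shared core gives a measured number rather than a limit, so this step is a floor and its full size cannot be read. Compound 3 remains a limit, not a number: the limit of < 2000 nM in this assay, at which 1 of the 4 values shown sits.

The five-membered aromatic ring and the methylcarbamoyl enter together, so the compounds shown do not assign the step to either one. Open, going by these compounds, are 1-methyl-1H-pyrazol-5-yl without the methylcarbamoyl, and an amine or a carboxylic acid on the same aromatic carbon.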